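A few compounds are considered here, and "the series" means these few. Any claim that something is new, unique, unknown or untested is made for them only; others in the source may bear on it.

Of the compounds shown here, two have so far been measured in an ADME assay on the whole organism (strain Sprague-Dawley) for pharmacokinetics, with Rattus norvegicus as the target, at a dose of 2 mg/kg by the oral route; on this read-out higher numbers stand for higher oral bioavailability and lower numbers for lower oral bioavailability. Compound 1 (`COc1ccc2c(OCc3nnc4ccc(-c5cc(F)c(F)c(F)c5)nn34)ccnc2c1`) gives 22%, and compound 2 (`COc1cnc2ccn([C@H](C)c3nnc4c(F)cc(-c5cc(C)no5)cn34)c(=O)c2c1`) gives 31%. These two numbers lie within the usual scatter of each other, so compound 2 stands level with compound 1 on this read-out, and neither can be ranked over the other.

Compound 3 (`COCCOc1cnc2ccn([C@H](C)c3nnc4c(F)cc(-c5cc(C)no5)cn34)c(=O)c2c1`) is built from compound 2 by a single change: methoxymethyl in place of hydrogen on a saturated chain carbon bound to an oxygen on an aromatic ring. The same difference reads as methoxy to 2-methoxyethoxy.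

Among the compounds with values here, no two measured compounds differ in one place only, so the data hold no measured step to guide an expectation in this assay. The expectation therefore stays close to compound 2 at 31%. The estimated change is small and downward, a number 4 percentage points lower from compound 2 to compound 3 (within the scatter), and it is expected to remain within the scatter. For compound 3 the expected value is 27%, with an estimated range from 12% to 45%.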

Compound 3, oral bioavailability: 54%
The estimate for compound 3 lay 27 percentage points below the measured number, outside the stated range (above it).
By their numbers in this assay, from the lowest: compounds 1 and 2 (each within the scatter of the next); then compound 3.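

Within the data shown here, replacing methoxy by 2-methoxyethoxy gives, in this assay, a number 23 percentage points higher from compound 2 to compound 3 (beyond the scatter), and this is the first change in one place that can be read here. It shows that methoxymethyl in place of hydrogen is accepted on a saturated chain carbon bound to an oxygen on an aromatic ring, and that the oral bioavailability of this series responds to what is built out from that oxygen, a step larger than the usual scatter though still a modest one. Nothing at hand bears on the reason for this rise.

Going by these compounds, it remains open whether the step belongs to the greater length of the chain or to its added ether oxygen, and this single pair cannot tell the two apart; a plain propyl chain without that oxygen, or an amine or a carboxylic acid at the end of the chain, would speak to that question. Also open, on these data alone, is whether the same change would carry over to the different core of compound 1, which bears a methoxy group as well.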